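A Methyl Added to the Anilide of Compound 2

A few compounds are considered here, and "the series" means these few. Any claim that something is new, unique, unknown or untested is made for them only; others in the source may bear on it.

Two compounds in this series share one core and differ only in the group attached to the carbonyl carbon. Compound 1 `COc1cc(-c2nnc(SCC(=O)c3ccccc3F)n2N)cc(OC)c1OC` carries a 2-fluorophenyl there; in a functional assay on PC-3 cells (Homo sapiens) for antiproliferative activity, read by MTT assay, with a stated time of 48 h (on this read-out lower numbers stand for stronger inhibition and higher numbers for weaker inhibition), compound 1 gives 43100 nM. Compound 2 `COc1cc(-c2nnc(SCC(=O)Nc3ccccc3)n2N)cc(OC)c1OC` carries an anilino instead, and in this assay compound 2 gives 37900 nM. The step of a 1.1-fold lower number from compound 1 to compound 2 (0.06 log units; within the scatter) shows that these two numbers cannot be told apart, so compound 2 stands alongside compound 1 rather than apart from it.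

Compound 3 `COc1cc(-c2nnc(SCC(=O)Nc3ccc(C)cc3)n2N)cc(OC)c1OC` takes the next step: methyl in place of hydrogen on an aromatic carbon, on the anilino of compound 2. Among the measured compounds shown here, no measured step in this set concerns a methyl, or any addition to that ring; the only measured step, a 1.1-fold lower number from compound 1 to compound 2 (0.06 log units; within the scatter), concerns an exchange at the carbonyl carbon and lay within the scatter. With nothing pointing either way, the expectation for compound 3 is a step of a 1.1-fold lower number from compound 2 to compound 3 (0.03 log units; within the scatter) in this assay, that is, no change beyond the scatter. Compound 3 is therefore expected to give about 35000 nM in this assay, most likely between 15000 nM and 80000 nM.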

Compound 3, half-maximal inhibitory concentration: 43100 nM
Compound 3: middle estimate off by 1.2-fold (0.09 log units), on the low side; the range from low to high includes it.
By their numbers in this assay, from the lowest: compounds 2, 1 and 3 (each within the scatter of the next).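

Among the compounds shown here, compound 3 gives the first reading of an added group on the anilino ring: methyl in place of hydrogen, para to a large group, is a step of a 1.1-fold higher number from compound 2 to compound 3 (0.06 log units; within the scatter) in this assay, so this small addition at this position leaves the two numbers indistinguishable. The larger exchange on the carbonyl carbon, (4-methylphenyl)amino in place of 2-fluorophenyl, reads no change at the digits printed from compound 1 to compound 3 (within the scatter), so all three groups tried on that carbon so far give numbers that lie together, with none standing apart. Nothing available explains why these numbers lie together.

Going by these compounds, a single methyl at a single place on the ring cannot show whether this position tolerates any change, so it remains open whether a longer chain such as butyl, an amine or a carboxylic acid in the same place would move the number beyond the scatter. Also open is what a methyl in place of the amide hydrogen would do, since every anilide shown here keeps that hydrogen.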